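The compounds below may be only part of what the source reports. "The series", "measured", "known", "first", "only" and "open" are said of these compounds alone.

Compounds measured in a functional assay on CHO cells for agonist activity at prostaglandin E2 receptor EP2 subtype (Homo sapiens), read by HTRF and cAMP accumulation, with a stated time of 30 min; on this read-out lower numbers stand for an effect already at smaller amounts and higher numbers for an effect only at larger amounts of compound:

compound 1, `O=C(O)c1csc([C@H]2CC[C@@H]3[C@@H](/C=C/[C@@H](O)COc4ccccc4)[C@H](O)C[C@@H]3O2)n1`: 7.9 nM
compound 2, `O=C(O)c1csc([C@H]2CC[C@@H]3[C@@H](COc4cccc(F)c4)[C@H](O)C[C@@H]3O2)n1`: 5.4 nM
compound 3, `O=C(O)c1csc([C@H]2CC[C@@H]3[C@@H](CCCCCOc4ccccc4)[C@H](O)C[C@@H]3O2)n1`: 28 nM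

Among these three numbers compound 2 holds the lowest one, at 5.4 nM in this assay. Compound 1, with its value of 7.9 nM, sits closest, and that gap lies within the scatter of repeated measurements, so no order between the two can be read from the numbers. Compound 3, at 28 nM, is the furthest away, and there the gap does lie beyond the scatter. Within the data shown here, no pair of measured compounds differs in a single place, so no step of known size is available for comparison.

Compound 4, `O=C(O)c1csc([C@H]2CC[C@@H]3[C@@H](COc4ccccc4Cl)[C@H](O)C[C@@H]3O2)n1`, is not yet measured. It differs from compound 2 by the change (2-chlorophenyl in place of 3-fluorophenyl on an oxygen on a saturated carbon). The shared core and the rest of the chain are unchanged; what changes is the halogen on the aromatic ring and the point at which it sits, as named in the two group names.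

Among the measured compounds shown here, with no measured step of this kind, the expectation rests on the closeness of compound 1 and compound 2 alone. The step of a 1.3-fold higher number from compound 2 to compound 4 (0.11 log units; within the scatter) is expected to be small, without a clear direction, and within the usual scatter. Compound 4 is therefore estimated at 7 nM, with a range from 2.5 nM to 20 nM.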

Compound 4, half-maximal effective concentration: 3.3 nM
For compound 4 the middle estimate is 2.1-fold (0.33 log units) above the measured one; the measured number falls inside the stated range.
By their numbers in this assay, from the lowest: compounds 4, 2 and 1 (each within the scatter of the next, the first and the last beyond it); then compound 3.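

Among these compounds, this is the first step measured at the aromatic ring on the oxygen, and in this assay replacing 3-fluorophenyl with 2-chlorophenyl gives a 1.6-fold lower number from compound 2 to compound 4 (0.21 log units; within the scatter). The two groups match in heavy-atom count and in their counts of hydrogen-bond donors and acceptors, yet differ in both the halogen and where it sits, and this double change stays within the scatter, so the pair shows no order and the read-out at this place holds across that exchange. No measurement given here speaks to what lies behind this step.

Since the halogen and its place change together, the step cannot be divided between them, and the compounds shown leave open how 2-fluorophenyl or 3-chlorophenyl would read at this place. Also open, going by these compounds, is whether this tolerance extends beyond halogens, for example to a phenyl ring carrying a methoxy group, a nitrile or a trifluoromethyl group, or to a plain phenyl on the same oxygen.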